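The source may report more compounds than this note shows. Statements on the series, on what has been measured and on what is new or still open speak of the compounds shown alone.

The series shares a single core, seen in compound 1 `Fc1ccc(-c2nn3c(NC4CCCC4)cccc3c2-c2cccnc2F)cc1`, compound 2 `Nc1nccc(-c2c(-c3ccc(F)cc3)nn3c(NC4CCCC4)cccc23)n1` and compound 3 `Nc1n[nH]cc1-c1c(-c2ccc(F)cc2)nn2c(NC3CCCC3)cccc12`, differing only in the aromatic group attached to the five-membered ring of that core. In an ADME assay on Vero cells (Chlorocebus sabaeus) for cytotoxicity (a higher number here means that more compound is tolerated, a lower number that less compound is tolerated), compound 2 gives 46000 nM, while compound 3 gives 20000 nM; for compound 1 the entry reads "not determined" (no result reported), so no number is available for it. Within the data shown here, compound 3 therefore holds the lowest of the two available numbers, and the one step that connects them, a 2.3-fold lower number from compound 2 to compound 3 (0.36 log units; beyond the scatter), is the only measured guide to how this position affects the read-out.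

Compound 4 `Fc1ccc(-c2nn3c(NC4CCCC4)cccc3c2-c2ccncc2)cc1` is the next step from compound 3: pyridin-4-yl in place of 3-amino-1H-pyrazol-4-yl on an aromatic carbon. Among the measured compounds shown here, the aminopyrazole that lowered the number relative to compound 2 is now itself removed in favour of a six-membered ring carrying no hydrogen-bond donor, which on the sole available step, a 2.3-fold lower number from compound 2 to compound 3 (0.36 log units; beyond the scatter), points toward a number closer to that of compound 2 than of compound 3. The expected step is a 1.6-fold higher number from compound 3 to compound 4 (0.20 log units; within the scatter), a modest rise, with compound 4 estimated at 32000 nM (range 12000 nM to 90000 nM).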

Compound 4, half-maximal cytotoxic concentration: 20000 nM
Estimate against measurement, compound 4: 1.6-fold (0.20 log units) above; measured number inside the range.
By their numbers in this assay, from the lowest: compounds 3 and 4 (each within the scatter of the next); then compound 2.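

In this assay the exchange of 3-amino-1H-pyrazol-4-yl for pyridin-4-yl gives no change at the digits printed from compound 3 to compound 4 (within the scatter) and so shows that this position does not separate a five-membered ring bearing hydrogen-bond donors from a six-membered ring bearing none. Replacing 2-aminopyrimidin-4-yl with pyridin-4-yl gives a 2.3-fold lower number from compound 2 to compound 4 (0.36 log units; beyond the scatter), so a second, different group now stands beyond the scatter from compound 2, which holds the highest number of the three. No supporting measurement bears on why these numbers fall as they do.

The compounds shown leave open whether an amine placed on the pyridin-4-yl ring of compound 4 would bring the number back toward that of compound 2. Compound 1 offers no number to compare, so its group remains unplaced in this order.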